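Trimming a phenoxymethyl to a hydroxy on a benzofuran-type antagonist

The source may hold more compounds than are shown below. What is called first, only, known or untested is meant among the compounds shown, and "the series" means these compounds.

Of the compounds shown here, three have been measured in a functional assay on HEK293 cells for antagonist activity at proteinase-activated receptor 4 (Homo sapiens), read by FLIPR and calcium flux, with a stated time of 30 min; a lower number here means a stronger inhibitor, a higher number a weaker inhibitor. Compound 1 `c1ccc2oc(-c3cn4nc(C5CC5)sc4n3)cc2c1` gives 530 nM in this assay. For the measured compounds named here, compound 2 `COc1nn2cc(-c3cc4ccccc4o3)nc2s1` gives 4 nM, and the single one-place step seen so far, a 130-fold lower number from compound 1 to compound 2 (2.12 log units; beyond the scatter), is a large one. Compound 3 `COc1cc(OCc2cccc(COc3ccccc3)c2)c2cc(-c3cn4nc(OC)sc4n3)oc2c1` gives 3.2 nM, the lowest of the three numbers; its gap to compound 2 lies within the scatter, while its gap to compound 1 lies well beyond it.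

Compound 4 `COc1cc(OCc2cccc(O)c2)c2cc(-c3cn4nc(OC)sc4n3)oc2c1` has not yet been measured. It differs from compound 3 in one place: hydroxy in place of phenoxymethyl on an aromatic carbon. The change sits on an aromatic carbon of a six-membered aromatic ring of carbon only, meta to a large group. Going by the values given here, no measured step in this assay concerns this kind of change; the step from compound 1 to compound 2 alters a different group on a different ring and so gives no direct guide. Compound 2, which lacks the whole phenoxymethyl-bearing side arm, still gives 4 nM, so the arm contributes little on the numbers shown. Compound 4 is therefore expected to stay close, with a step of a 1.9-fold higher number from compound 3 to compound 4 (0.27 log units; within the scatter) expected at most. The estimate for compound 4 is 6 nM, within a range of 1.5 nM to 30 nM.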

Compound 4, half-maximal inhibitory concentration: 3.1 nM
Compound 4: the middle estimate sits 1.9-fold (0.29 log units) above what was measured, within the range that was stated.
By their numbers in this assay, from the lowest: compounds 4, 3 and 2 (each within the scatter of the next); then compound 1.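

In this assay, the exchange of phenoxymethyl for hydroxy gives a 1.0-fold lower number from compound 3 to compound 4 (0.01 log units; within the scatter), so the two numbers cannot be told apart. At this place, meta to a large group, a group of eight heavy atoms with its own aromatic ring and a single oxygen bearing a hydrogen-bond donor are therefore equally compatible with a low nanomolar number, which shows that the outer ring of the phenoxymethyl is not needed to reach it. Nothing available here gives a reason for this agreement.

On these data alone, it remains open whether other groups on this aromatic carbon, such as an amine, a carboxylic acid or a longer chain, would give a similar number. As far as these compounds go, it is also open whether a plain hydrogen there would do as well as the hydroxy.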